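This account rests on a few compounds, and the source may have more. Where it says the series, first, only, none or still open, it means among the compounds named here.

Measured so far:
compound 1 `Nc1nc(Cl)c2ncn(Cc3ccc(CCl)cc3)c2n1` gives > 100000 nM
compound 2 `ClCc1cccc(Cn2cnc3nc(Cl)nc(Cl)c32)c1` gives 38900 nM
compound 3 `ClCc1ccc(Cn2cnc3ncnc(Cl)c32)cc1` gives 7760 nM

Three close relatives of one fused core were tested in a functional assay on UACC-257 cells (Homo sapiens) for cytotoxicity, read by sulforhodamine B assay, with a stated time of 48 h; a lower number here means that less compound is tolerated, a higher number that more compound is tolerated. For compound 1 the result is a limit of the assay rather than a number, (the limit of > 100000 nM in this assay, at which 1 of the 3 values shown sits). Among the two numbers, compound 2 stands highest, so it is the better tolerated of the pair; compound 3 sits a good way lower, and that gap is larger than the usual scatter of repeated measurements.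

Compound 4 `ClCc1cccc(Cn2cnc3ncnc(Cl)c32)c1` has not yet been measured in this assay. Compared with compound 2 the difference is small: hydrogen in place of chloro on an aromatic carbon. Within the data shown here, compound 3 likewise carries only one chloro on its core, and its number in this assay is lower than that of compound 2. On that basis the expected step of a 3.2-fold lower number from compound 2 to compound 4 (0.51 log units; beyond the scatter) is a decrease, beyond the scatter. Compound 4 is therefore estimated at 12000 nM in this assay, within a range from 4000 nM to 40000 nM.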

Compound 4, concentration lethal to 50% of the cells: 18600 nM
Compound 4: the middle estimate sits 1.6-fold (0.19 log units) below what was measured; low and high end bracket the measured number.
By their numbers in this assay, from the lowest: compound 3; then compound 4; then compound 2. At a limit, above all of these: compound 1.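

Among these compounds, this is the first pair here that differs in one place only, so the chloro on the aromatic carbon between two ring nitrogen atoms can be judged on its own in this assay for the first time. Replacing it with hydrogen gives a 2.1-fold lower number from compound 2 to compound 4 (0.32 log units; beyond the scatter), so the chloro at this position goes with more compound being tolerated, although this rests on a single pair. Nothing measured here explains this step.

Still open, as far as these compounds go, is whether another group on this carbon, such as a fluoro, a methyl or a methoxy group, would move the number the same way or further. From the compounds shown here alone, it is also open whether the same change would give a similar step with the chloromethyl group placed as in compound 3.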